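The source may hold more compounds than are shown below. What is called first, only, known or untested is meant among the compounds shown, and "the series" means these compounds.

Working notes on the series. Among the compounds with values here, in an ADME assay on cells (Peritoneal macrophage, Mus musculus, strain Swiss) for cytotoxicity, with a stated time of 24 h (on this read-out lower numbers stand for higher toxicity in this test and higher numbers for lower toxicity in this test), compound 1 (`O=C1C=CC(=O)C(I)=C1`) gives 86000 nM, the highest of the three numbers so far. Compound 2 (`O=C1C=CC(=O)C(Br)=C1`) gives 34400 nM, and compound 3 (`CC(C)(C)C1=CC(=O)C(I)=CC1=O`) gives 35900 nM.

Compound 4 (`COC1=C(I)C(=O)C=CC1=O`) is one change away from compound 1: methoxy in place of hydrogen on a double-bonded ring carbon. Methoxy stands in place of hydrogen on a double-bonded ring carbon, next to the ring atom that bears the iodo group.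

Within the data shown here, no methoxy compound has been measured, so the evidence is indirect. Among the measured compounds shown here, the nearest precedent is compound 3, also a replacement of hydrogen on a double-bonded ring carbon, with a 2.4-fold lower number from compound 1 to compound 3 (0.38 log units; beyond the scatter), a modest step beyond the scatter. The other measured change, bromo in place of iodo, gives a 2.5-fold lower number from compound 1 to compound 2 (0.40 log units; beyond the scatter), also modest, but it bears only on the size of step seen so far on this core, not on the new group. With a single precedent for replacing hydrogen, a modest move to a lower number is expected, and a result within the scatter of compound 1 would not be surprising.

The expected step is a 1.7-fold lower number from compound 1 to compound 4 (0.24 log units; within the scatter). Compound 4 is estimated at 50000 nM, with an expected range from 20000 nM to 110000 nM.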

Compound 4, concentration lethal to 50% of the cells: 32600 nM
The estimate for compound 4 lay 1.5-fold (0.19 log units) above the measured number; the range from low to high includes it.
By their numbers in this assay, from the lowest: compounds 4, 2 and 3 (each within the scatter of the next); then compound 1.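

In this assay, methoxy in place of hydrogen on a double-bonded ring carbon, next to the ring atom that bears an iodo group, gives a 2.6-fold lower number from compound 1 to compound 4 (0.42 log units; beyond the scatter), so a change at this place does register beyond the scatter, though the step is modest. With the tert-butyl replacement of hydrogen, which gives a 2.4-fold lower number from compound 1 to compound 3 (0.38 log units; beyond the scatter), there are now two replacements of hydrogen on the core of compound 1, and both lead to a lower number by a modest step, with neither of the two going against that direction. Nothing measured here accounts for the step seen with methoxy.

The compounds shown leave open whether this step belongs to methoxy itself or would follow any replacement of hydrogen at this place, which an amine, a carboxylic acid or a longer alkoxy chain there would help to settle. They also leave open whether the methoxy step would keep its direction and size on the core of compound 2, with bromo in place of iodo.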